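A Methyl Step Repeated on a Second Core

This account rests on a few compounds, and the source may have more. Where it says the series, first, only, none or still open, it means among the compounds named here.

Compound 1 `N/C(=N\NC(=S)N1CCOCC1)c1ccccn1` is the starting point. In a functional assay on A-431 cells (Homo sapiens) for cytotoxicity, read by MTT assay, with a stated time of 72 h, tested at 100 uM (a higher number here means more inhibition of growth at the concentration tested, a lower number less inhibition of growth), compound 1 gives 84.6%. Compound 2 `N/C(=N\NC(=S)N1CCCCC1)c1ccccn1` differs from it by piperidin-1-yl in place of morpholin-4-yl on a thiocarbonyl carbon; the step of a number 1 percentage points higher from compound 1 to compound 2 (within the scatter), and compound 2 gives 85.6%. Compound 3 `Cc1cccc(/C(N)=N/NC(=S)N2CCOCC2)n1` differs from compound 1 by methyl in place of hydrogen on an aromatic carbon; the step of a number 0.2 percentage points higher from compound 1 to compound 3 (within the scatter), and compound 3 gives 84.8%. All three numbers lie within the scatter of one another, so no order among them can be claimed.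

Compound 4 `Cc1ccnc(/C(N)=N/NC(=S)N2CCCCC2)c1` is not yet measured. It differs from compound 2 by methyl in place of hydrogen on an aromatic carbon. This is the same kind of change as that from compound 1 to compound 3, but the place is not the same: in compound 3 the methyl sits next to the ring nitrogen, in compound 4 it sits opposite the ring nitrogen, both meta to a large group. The difference between the two cores is given by piperidin-1-yl in place of morpholin-4-yl on a thiocarbonyl carbon. Compound 4 is expected to move by a number 0.4 percentage points higher from compound 2 to compound 4 (within the scatter), because the earlier methyl step a number 0.2 percentage points higher from compound 1 to compound 3 (within the scatter) stayed within the scatter. Compound 4 is therefore estimated at 86%, with a range from 79% to 92%.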

Compound 4, percent growth inhibition at one concentration: 77.6%
Estimate against measurement, compound 4: 8.4 percentage points above; the measured number lies below the stated range.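

In this assay, methyl in place of hydrogen on an aromatic carbon gives a number 8 percentage points lower from compound 2 to compound 4 (within the scatter), so this step, like the earlier one, stays inside the scatter. Set side by side, the two steps cannot be told apart: the same change on two cores in this assay, a number 0.2 percentage points higher (within the scatter) from compound 1 to compound 3 and a number 8 percentage points lower (within the scatter) from compound 2 to compound 4, 8.2 percentage points apart, within the scatter of two such steps

This shows that the change carries from the core of compound 1 to the core of compound 2 with no difference that can be claimed, but it does not show that the two steps are equal. The methyl does not stand in the same place on the two cores, and the compounds shown do not vary the core and the place one at a time.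

The compounds shown leave open whether a methyl in the place it holds in compound 3 would give a similar step on the core of compound 2. Also open, going by these compounds, is whether an amine, a carboxylic acid or a longer chain in place of the methyl would give a step beyond the scatter.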